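Chloro for Fluoro on the Anilide Ring: Expecting Compound 4

The source may report more compounds than this note shows. Statements on the series, on what has been measured and on what is new or still open speak of the compounds shown alone.

Of the compounds shown here, three sharing one core have been measured in a functional assay on MGC-803 cells (Homo sapiens) for inhibition, read by MTT assay, with a stated time of 72 h; a lower number here means a stronger inhibitor, a higher number a weaker inhibitor. Compound 1 `O=C(CSc1nc(Nc2ccccc2)c2ccccc2n1)Nc1cccc(F)c1` gives 12700 nM. Compound 2 `O=C(CSc1nc(Nc2ccccc2)c2ccccc2n1)Nc1cccc(Cl)c1` gives 14300 nM. Compound 3 `O=C(CSc1nc(Nc2ccccc2)c2ccccc2n1)Nc1ccc(F)cc1` gives > 50000 nM, which is a limit of the assay rather than a number, as noted in the limit of > 50000 nM in this assay, at which 1 of the 3 values shown sits.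

Compound 2 differs from compound 1 by chloro in place of fluoro on an aromatic carbon, and this change produced a 1.1-fold higher number from compound 1 to compound 2 (0.05 log units; within the scatter). Compound 3 differs from compound 1 by 4-fluorophenyl in place of 3-fluorophenyl on an amide-type nitrogen, and that rearrangement gave an at least 3.9-fold higher number from compound 1 to compound 3 (0.59 log units; beyond the scatter). The corresponding comparison from compound 2 gave an at least 3.4-fold higher number from compound 2 to compound 3 (0.54 log units; beyond the scatter).

Compound 4 `O=C(CSc1nc(Nc2ccccc2)c2ccccc2n1)Nc1ccc(Cl)cc1` has not yet been measured in this assay. It differs from compound 3 by chloro in place of fluoro on an aromatic carbon. Within the data shown here, this is the same kind of change as the one from compound 1 to compound 2, but not the same: in the earlier pair the halogen sits meta to a large group, whereas in compound 4 it sits para to a large group.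

Because a 1.1-fold higher number from compound 1 to compound 2 (0.05 log units; within the scatter) was within the scatter, the step from compound 3 to compound 4 is expected to be small as well, and since compound 3 already stands at a limit, compound 4 is estimated to give 60000 nM, within 30000 nM to 150000 nM, corresponding to an expected step that the limit leaves unreadable from compound 3 to compound 4. It is expected that compound 4 will also most likely be reported only as a limit.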

Compound 4, half-maximal inhibitory concentration: 40400 nM
The estimate for compound 4 lay 1.5-fold (0.17 log units) above the measured number; the range from low to high includes it.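

In this assay, chloro in place of fluoro can be followed on two cores, but the second pair can be read only in part, as compound 3 gives > 50000 nM, which is a limit of the assay and not a number: the limit of > 50000 nM in this assay, at which 1 of the 4 values shown sits. On the core of compound 3, the change gave an at least 1.2-fold lower number from compound 3 to compound 4 (0.09 log units; that floor lies within the scatter), and set beside the earlier pair, the result reads: the same change on two cores in this assay, a 1.1-fold higher number (0.05 log units; within the scatter) from compound 1 to compound 2 and an at least 1.2-fold lower number (0.09 log units; that floor lies within the scatter) from compound 3 to compound 4; the limit leaves it open whether they differ. This shows no sign that the swap of halogen behaves differently when it is carried from one core to the other, but it does not show that its effect transfers, and the steps that can be read in full are those that also move the halogen, with a 2.8-fold higher number from compound 2 to compound 4 (0.45 log units; beyond the scatter) and a 3.2-fold higher number from compound 1 to compound 4 (0.50 log units; beyond the scatter).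

The compounds shown leave open whether bromo, methoxy or a plain hydrogen in the same place para to a large group would follow the two halogens. They also leave open how an amine or a carboxylic acid on the anilide ring, or a longer chain in place of the one carrying the carbonyl, would read in this assay.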